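Swapping a carboxypyrrolidine for morpholine on the carbonyl carbon

The source may report more compounds than this note shows. Statements on the series, on what has been measured and on what is new or still open speak of the compounds shown alone.

Compound 1 `O=C(O)[C@@H]1CCCN1C(=O)/C=C/c1ccncc1-c1ccc2ccccc2c1`: "not determined" (no result reported)
Compound 2 `O=C(/C=C/c1ccncc1-c1ccc2cc[nH]c2c1)N1CCOCC1`: > 30000 nM

These compounds were tested in a functional assay on HCT-116 cells (Homo sapiens) for inhibition, read by MTT assay, with a stated time of 72 h; on this read-out lower numbers stand for stronger inhibition of growth and higher numbers for weaker inhibition of growth. Compound 1 has no place on this scale, because its entry reads "not determined" (no result reported). The only other result is a limit and not a number: compound 2 gives > 30000 nM.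

The next compound to be measured is compound 3 `O=C(/C=C/c1ccncc1-c1ccc2ccccc2c1)N1CCOCC1`. It keeps the core of compound 1 but has morpholin-4-yl in place of 2-carboxypyrrolidin-1-yl on a carbonyl carbon.

Without a number for compound 1, this step has no starting point, so neither its size nor its direction in this assay can be predicted. For the measured compounds named here, compound 2 offers the only guide, as it also carries morpholin-4-yl on a carbonyl carbon, though its core differs from that of compound 3. Weak growth inhibition, possibly too weak to yield a number, is expected of compound 3 on the strength of the limit shown by compound 2, > 30000 nM. Compound 3 is expected to give about 20000 nM, with an estimated range from 5000 nM to 60000 nM.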

Compound 3, concentration for 50% growth inhibition: 6040 nM
Beside the measured number, compound 3's estimate is 3.3-fold (0.52 log units) above it; measured number inside the range.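

No new step can be read in this assay: compound 1 has no number there, so the change from compound 1 to compound 3 has neither a size nor a direction. Compound 2 gives > 30000 nM, which is a limit and not a number. Still open, as far as these compounds go, is how 2-carboxypyrrolidin-1-yl and morpholin-4-yl compare on one shared core.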